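The compounds below may be only part of what the source reports. "The series", "measured", "known", "first", "only" and "open" are said of these compounds alone.

Working notes on the series. Compound 2 `COc1cc(-c2nn(-c3cccc(NC(=O)Nc4cc(C(F)(F)F)cc(C(F)(F)F)c4)c3)cc2-c2ccncc2)ccc1Cl` serves as the reference point. In a functional assay on SNB-75 cells (Homo sapiens) for inhibition, read by sulforhodamine B assay, with a stated time of 48 h (on this read-out lower numbers stand for higher toxicity in this test and higher numbers for lower toxicity in this test), compound 2 gives 5310 nM, which is the lowest of the two numbers in hand. Going by the values given here, compound 3 `COc1cc(-c2nn(-c3cccc(NC(=O)Nc4cccc(C(F)(F)F)c4)c3)cc2-c2ccncc2)ccc1Cl` gives in this assay 50000 nM, and the step of a 9.4-fold higher number from compound 2 to compound 3 (0.97 log units; beyond the scatter) is the only measured step that leads away from compound 2. Compound 1 `O=C(Nc1cccc(-n2cc(-c3ccncc3)c(-c3ccc(Cl)c(O)c3)n2)c1)Nc1cccc(C(F)(F)F)c1` is reported in this assay only as a limit, > 32500 nM.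

The candidate is compound 4 `O=C(Nc1cccc(-n2cc(-c3ccncc3)c(-c3ccc(Cl)c(O)c3)n2)c1)Nc1cc(C(F)(F)F)cc(C(F)(F)F)c1`. Relative to compound 2 it carries hydrogen in place of methyl on an oxygen on an aromatic ring. Among the compounds with values here, the single measured step that touches the same change on the oxygen is a step that the limit leaves unreadable from compound 1 to compound 3, and its size cannot be read because the limit of > 32500 nM in this assay, at which 1 of the 3 values shown sits, leaves the value of compound 1 open. The methyl-to-hydrogen exchange on the oxygen therefore has no readable precedent in this set; what can be said is that compound 1 and compound 3 both sit in the high region of the scale, which gives no sign of a large move in either direction. The expected step of a 1.3-fold higher number from compound 2 to compound 4 (0.12 log units; within the scatter) in this assay is accordingly small, within or close to the scatter. Compound 4 is estimated at 7000 nM, with a range from 2500 nM to 25000 nM.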

Compound 4, concentration lethal to 50% of the cells: 7030 nM
Compound 4: the middle estimate sits 1.0-fold (0.00 log units) below what was measured, and the stated range covers the measured number.
By their numbers in this assay, from the lowest: compounds 2 and 4 (each within the scatter of the next); then compound 3.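

Going by these compounds alone, on the exchange of 4-chloro-3-methoxyphenyl for 4-chloro-3-hydroxyphenyl, the compounds with two trifluoromethyl groups give the first readable pair in this assay: a 1.3-fold higher number from compound 2 to compound 4 (0.12 log units; within the scatter), so methoxy and hydroxy at this place are not separated on this core. Compound 4 also gives a second reading of the trifluoromethyl change, now on the hydroxy compounds, as an at least 4.6-fold lower number from compound 1 to compound 4 (0.66 log units; beyond the scatter), where the number for compound 1 is a limit and the step is therefore a bound and not a size. The added trifluoromethyl thus goes with the lower number on both the methoxy and the hydroxy compounds, though the sizes of the two steps cannot be set against each other: the same change on two cores in this assay, a 9.4-fold higher number (0.97 log units; beyond the scatter) from compound 2 to compound 3 and an at least 4.6-fold higher number (0.66 log units; beyond the scatter) from compound 4 to compound 1; the limit leaves it open whether they differ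

The compounds shown leave open whether an ethoxy group or a longer alkoxy chain in place of methoxy would stay level with compound 2 and compound 4, or whether an amine in place of hydroxy would do so. They also leave open whether a nitrile or a carboxylic acid in place of the added trifluoromethyl would go with the lower number as well.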